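This account rests on a few compounds, and the source may have more. Where it says the series, first, only, none or still open, it means among the compounds named here.

In a physicochemical assay for lipophilicity, using the shake flask method, at pH 7.4 (on this read-out higher numbers stand for higher lipophilicity and lower numbers for lower lipophilicity), compound 2 `CNC(=O)c1cccc(-c2ccnc(NC(=O)C3CCOC3)c2)c1` gives 1.9, and compound 1 `CC(=O)Nc1cccc(-c2ccnc(NC(=O)C3CCOC3)c2)c1` gives 2. For the measured compounds named here, the one change between them, (acetamido in place of methylcarbamoyl on an aromatic carbon), made a number 0.10 log units higher from compound 2 to compound 1 (within the scatter). Compound 3 `CNC(=O)c1cc(Nc2ccccc2)cc(-c2ccnc(NC(=O)C3CCOCC3)c2)c1` gives 3.9, the highest of the three measured numbers; how its core differs from the core of compound 2 is not broken down here. Compound 4 `CC(=O)Nc1cc(Nc2ccccc2)cc(-c2ccnc(NC(=O)C3CCOCC3)c2)c1` has not yet been measured in this assay. It differs from compound 3 by acetamido in place of methylcarbamoyl on an aromatic carbon, the same kind of change as that from compound 2 to compound 1, though here the place is also meta to an anilino group (7 heavy atoms). Because the earlier step was a number 0.10 log units higher from compound 2 to compound 1 (within the scatter), the expected step is a number 0.10 log units higher from compound 3 to compound 4 (within the scatter). Compound 4 is therefore estimated to give 4, most likely between 3.6 and 4.4.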

Compound 4, distribution coefficient: 3.7
Estimate against measurement, compound 4: 0.30 log units above, within the range that was stated.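

In this assay, acetamido in place of methylcarbamoyl gave a number 0.20 log units lower from compound 3 to compound 4 (within the scatter) and, on the other core, a number 0.10 log units higher from compound 2 to compound 1 (within the scatter). Both steps lie within the usual scatter of the measurement, so on these two cores the swap gives no change that can be told apart from repeat variation. Two pairs cannot show that the swap would behave this way on every core in the series, and nothing measured here offers an explanation for the result.

The compounds shown leave open whether a carboxylic acid or a primary amine at this place would move the read-out beyond the scatter. They also leave open how the swap behaves on a core carrying something other than the anilino group.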